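The source may hold more compounds than are shown below. What is called first, only, known or untested is meant among the compounds shown, and "the series" means these compounds.

Compound 1 `O=C(CSc1nc(Nc2ccccc2)c2ccccc2n1)Nc1ccccc1Br` is the starting point of these notes. Among the measured compounds shown here, in a functional assay on MGC-803 cells (Homo sapiens) for inhibition, read by MTT assay, with a stated time of 72 h (on this read-out lower numbers stand for stronger inhibition and higher numbers for weaker inhibition), compound 1 gives 18600 nM, the highest number of the two measured so far. Compound 2 `C=CC(=O)Nc1cccc(NC(=O)CSc2nc(Nc3ccccc3)c3ccccc3n2)c1` gives 7310 nM in this assay, and the step of a 2.5-fold lower number from compound 1 to compound 2 (0.41 log units; beyond the scatter) shows what a replacement of the 2-bromophenyl group on the amide-type nitrogen can do. Compound 3 `O=C(CSc1nc(Nc2ccccc2)c2ccccc2n1)Nc1ccc(C(F)(F)F)cc1` varies the same position in a different way: 4-(trifluoromethyl)phenyl in place of 2-bromophenyl on an amide-type nitrogen. For the measured compounds named here, the only measured step that bears on this change is a 2.5-fold lower number from compound 1 to compound 2 (0.41 log units; beyond the scatter), and it involves a different entering group, so it gives only a loose guide to size and direction. A modest step toward a lower number is therefore expected, but with wide uncertainty. Compound 3 is expected to give about 12000 nM in this assay, within a range from 4000 nM to 36000 nM, which corresponds to an expected step of a 1.6-fold lower number from compound 1 to compound 3 (0.19 log units; within the scatter).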

Compound 3, half-maximal inhibitory concentration: 8670 nM
Beside the measured number, compound 3's estimate is 1.4-fold (0.14 log units) above it; the measured number falls inside the stated range.
By their numbers in this assay, from the lowest: compounds 2 and 3 (each within the scatter of the next); then compound 1.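

In this assay, the 4-(trifluoromethyl)phenyl group on the amide-type nitrogen gives a 2.1-fold lower number from compound 1 to compound 3 (0.33 log units; beyond the scatter), so a second replacement of the 2-bromophenyl group, and not only the 3-((vinylcarbonyl)amino)phenyl group, gives a step beyond the scatter. The two entering groups cannot be told apart here, with a 1.2-fold higher number from compound 2 to compound 3 (0.07 log units; within the scatter), so among these three compounds the vinylcarbonyl amide is not required to reach the level of compound 2. No measurement on hand gives a reason for either step.

The compounds shown leave open whether the steps reflect the loss of the 2-bromophenyl group or the arrival of the new groups, and a plain phenyl group on the amide-type nitrogen would bear on that. From the compounds shown here alone, how an amine or a carboxylic acid on this ring would read also remains open.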